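The source may hold more compounds than are shown below. What is called first, only, known or untested is meant among the compounds shown, and "the series" means these compounds.

Working notes on the sulfonamide series.

Compound 1 `CC(=O)NC1CCN(S(=O)(=O)c2ccc(F)cc2)CC1` gives 0.1 mg/kg in a functional assay on the whole organism with Mus musculus as the target, with a stated time of 20 min; on this read-out higher numbers stand for an effect only at larger amounts of compound and lower numbers for an effect already at smaller amounts. Compound 2 `CC(C)S(=O)(=O)N(C)c1ccc(N(C)S(=O)(=O)c2ccc(F)cc2)cc1` gives 1 mg/kg in this assay, and compound 3 `CC(C)S(=O)(=O)Nc1ccc(N(C)S(=O)(=O)c2ccc(F)cc2)cc1` gives 1 mg/kg in this assay. Compound 3 therefore stands level with compound 2 at the digits given, the two sharing the highest number of the three, while compound 1 lies furthest away, beyond the scatter.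

Among the compounds with values here, one measured step bears on the next change: no change at the digits printed from compound 2 to compound 3 (within the scatter). Compound 4 `CC(C)S(=O)(=O)Nc1ccc(NS(=O)(=O)c2ccc(F)cc2)cc1` differs from compound 3 by hydrogen in place of methyl on a sulfonamide nitrogen. Because the earlier step of no change at the digits printed from compound 2 to compound 3 (within the scatter) stayed within the scatter, no movement beyond the scatter is expected in this assay here either. The expected step is no change at the digits printed from compound 3 to compound 4 (within the scatter). Compound 4 is estimated at 1 mg/kg, in the range 0.3 mg/kg to 3 mg/kg.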

Compound 4, minimum effective dose: 10 mg/kg
Compound 4: the middle estimate sits 10-fold (1.00 log units) below what was measured, outside the stated range (above it).
By their numbers in this assay, from the lowest: compound 1; then compounds 2 and 3 (each within the scatter of the next); then compound 4.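

In this assay, hydrogen in place of methyl on the sulfonamide nitrogen that still carries methyl in compound 3 gives a 10-fold higher number from compound 3 to compound 4 (1.00 log units; beyond the scatter), whereas the same exchange on the other sulfonamide nitrogen gave no change at the digits printed from compound 2 to compound 3 (within the scatter). The outcome of this change therefore depends on which sulfonamide nitrogen carries it, and only the second exchange moves the number beyond the scatter. Nothing available explains the difference between the two nitrogens.

The compounds shown compare only methyl and hydrogen at this nitrogen. On these data alone, how an ethyl group or a longer chain there would read remains open.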